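A Sulfur Substituent Exchange on Compound 2

This account rests on a few compounds, and the source may have more. Where it says the series, first, only, none or still open, it means among the compounds named here.

Of the compounds shown here, three sharing one core have been measured in a functional assay on DU-145 cells (Homo sapiens) for inhibition, read by trypan blue exclusion, with a stated time of 96 h; on this read-out higher numbers stand for weaker inhibition of growth and lower numbers for stronger inhibition of growth. Compound 1 `COc1ccc(/C=C(/Sc2ccc(C)cc2)C(=O)c2ccc(Cl)cc2)cc1O` gives 1000 nM, and compound 2 `Cc1ccc(S/C(=C/c2ccc[nH]2)C(=O)c2ccc(Cl)cc2)cc1` gives 10000 nM. Compound 3 `Cc1ccc(S/C(=C/c2ccc(Cl)cc2Cl)C(=O)c2ccc(Cl)cc2)cc1` gives 10000 nM, so compound 2 stands level with compound 3, the pair sharing the highest number of the three.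

Compound 4 `O=C(/C(=C\c1ccc[nH]1)SCc1ccc(Cl)cc1)c1ccc(Cl)cc1` keeps the 1H-pyrrol-2-yl group of compound 2 and carries 4-chlorobenzyl in place of 4-methylphenyl on a sulfur.

The measured steps all concern another place, the group on a double-bonded chain carbon. Leaving 3-hydroxy-4-methoxyphenyl for 1H-pyrrol-2-yl gave a 10-fold higher number from compound 1 to compound 2 (1.00 log units; beyond the scatter), and leaving it for 2,4-dichlorophenyl gave a 10-fold higher number from compound 1 to compound 3 (1.00 log units; beyond the scatter), both beyond the scatter. Exchanging those two replacements gave no change at the digits printed from compound 2 to compound 3 (within the scatter), within the scatter. None of these steps alters the group on sulfur, so the data offer no direct measure of the present change, and its size remains uncertain.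

The expectation therefore rests on compound 2 at 10000 nM, and no shift beyond the scatter is expected in this assay. The expected step is a 1.3-fold lower number from compound 2 to compound 4 (0.10 log units; within the scatter). For compound 4 the estimated value is 8000 nM, with an expected range from 2500 nM to 20000 nM.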

Compound 4, concentration for 50% growth inhibition: 10000 nM
Estimate against measurement, compound 4: 1.3-fold (0.10 log units) below; measured number inside the range.
By their numbers in this assay, from the lowest: compound 1; then compounds 2, 3 and 4 (each within the scatter of the next).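

Among these compounds, the group on a sulfur had not been varied before, and the first reading of it in this assay is no change at the digits printed from compound 2 to compound 4 (within the scatter), so with 1H-pyrrol-2-yl held in place, 4-chlorobenzyl and 4-methylphenyl cannot be told apart in this assay. The change is not a small one on paper, since the entering group brings chlorine and replaces a ring bound directly to the sulfur with a benzyl group, yet the number does not move beyond the scatter. Nothing among the data accounts for this outcome, which is therefore recorded only as an observation.

The compounds shown leave open whether the same exchange would also leave the number unmoved with the 3-hydroxy-4-methoxyphenyl group of compound 1, the one member of the series whose number is lower. They also cannot separate the contribution of the chlorine from that of the benzyl group, which unsubstituted benzyl or 4-methylbenzyl on the sulfur could address, and they say nothing about a group of another kind there, such as an aminoethyl or a carboxymethyl chain.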